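Efficacy at a serotonin receptor: from compound 3 to compound 4

This account rests on a few compounds, and the source may have more. Where it says the series, first, only, none or still open, it means among the compounds named here.

Compound 1 `O=S(=O)(NCC1CCN(CCCc2c[nH]c3ccc(-n4cnnc4)cc23)CC1)c1ccccc1`: 73%
Compound 2 `c1ccc(CNCC2CCN(CCCc3c[nH]c4ccc(-n5cnnc5)cc34)CC2)cc1`: 101%
Compound 3 `c1ccc2c(c1)CCC2NCC1CCN(CCCc2c[nH]c3ccc(-n4cnnc4)cc23)CC1`: 78%

In a functional assay on CHO cells for activation of 5-hydroxytryptamine receptor 1D (Homo sapiens), read by GTPgammaS binding (a lower number here means a smaller maximal response, a higher number a larger maximal response), compound 3 stands second highest of the three; compound 1 lies within the scatter of it, whereas a number 23 percentage points lower from compound 2 to compound 3 (beyond the scatter) is beyond the scatter. Compound 4 `CC(CO)(NC1CCN(CCCc2c[nH]c3ccc(-n4cnnc4)cc23)CC1)c1ccccc1` differs from it by (1-(hydroxymethyl)-1-phenylethyl)amino in place of ((2,3-dihydro-1H-inden-1-yl)amino)methyl on a saturated ring carbon. The measured steps all exchange the group on the amine nitrogen and leave the rest unchanged: a number 28 percentage points higher from compound 1 to compound 2 (beyond the scatter), a number 5 percentage points higher from compound 1 to compound 3 (within the scatter), a number 23 percentage points lower from compound 2 to compound 3 (beyond the scatter). None of them places the amine directly on the ring carbon, so they bear only loosely on this change. Since all three measured values sit in a fairly narrow band, compound 4 is expected to show a number 2 percentage points higher from compound 3 to compound 4 (within the scatter), a step within the scatter. Compound 4 is estimated at 80%, with a range from 60% to 100%.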

Compound 4, largest response reached (reported as efficacy), in percent of the reference or control that the assay uses: 59%
The estimate for compound 4 lay 21 percentage points above the measured number, outside the stated range (below it).
By their numbers in this assay, from the lowest: compound 4; then compounds 1 and 3 (each within the scatter of the next); then compound 2.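

In this assay, the steps of a number 19 percentage points lower from compound 3 to compound 4 (beyond the scatter) and a number 42 percentage points lower from compound 2 to compound 4 (beyond the scatter) and a number 14 percentage points lower from compound 1 to compound 4 (beyond the scatter) all come with (1-(hydroxymethyl)-1-phenylethyl)amino on the saturated ring carbon, leaving compound 4 the lowest of the set. Compounds 1 and 3 lie within the scatter of each other, yet this change falls clearly below both, so the group at this position can lower the maximal response beyond what those two alone showed. Nothing available accounts for the drop.

Still open, going by these compounds, is whether the hydroxymethyl or the amine sitting directly on the ring carbon goes with the lower response. A plain methyl in place of the hydroxymethyl, or benzylamino directly on that carbon, would separate the two.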